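Switching a Benzyl Substituent for a Chloropyridinylmethyl Group

The source may report more compounds than this note shows. Statements on the series, on what has been measured and on what is new or still open speak of the compounds shown alone.

Of the compounds shown here, three from this series have been tested in a functional assay on SV5A8 cells (Homo sapiens) for cytotoxicity (a lower number here means a stronger inhibitor, a higher number a weaker inhibitor), and each returned only a limit. Compound 1 `Cc1ccc2c(NCc3ccc(NC(=O)C4CCN(Cc5ccccc5)CC4)cc3)nc(N3CCC3)nc2c1` gave > 8500 nM, a limit of the assay rather than a number. Compound 3 `Cc1ccc2c(NCc3ccc(NC(=O)C4CCN(Cc5ccccc5)CC4)cc3)nc(N3CCNC(CCO)C3)nc2c1` gave > 8420 nM, also a limit. The step that the two limits leave unreadable from compound 1 to compound 3 is therefore unreadable. Compound 2 `Cc1ccc(CN2CCC(C(=O)Nc3ccc(CNc4nc(N(C)C)nc5cc(C)ccc45)cc3)CC2)cc1` gave > 4150 nM, again a limit, so compound 2 stands at the limit of > 4150 nM in this assay, at which 1 of the 3 values shown sits, with no measured potency to compare against the other two.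

Compound 4 `Cc1ccc2c(NCc3ccc(NC(=O)C4CCN(Cc5cc(Cl)ccn5)CC4)cc3)nc(N(C)C)nc2c1` differs from compound 2 in one place: 4-chloropyridin-2-yl in place of 4-methylphenyl on a saturated chain carbon bound to an amine nitrogen in a ring. Going by the values given here, no measured step bears on this change, since the only step available, from compound 1 to compound 3, touches a different position and could not be read. Among the compounds with values here, with every value so far sitting at a limit, compound 4 is expected to remain weak in this assay. Compound 4 is estimated at 8000 nM, within a range of 2500 nM to 30000 nM. The expected step is a step that the limit leaves unreadable from compound 2 to compound 4, with a limit the most likely outcome.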

Compound 4, half-maximal inhibitory concentration: > 5400 nM
Compound 4: only a limit was reported; the forecaster's own chance of this, stated with the estimate: 70%; the middle value is on the limit's open side.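

Compound 2 and compound 4 each returned only a limit, so the swap of 4-methylphenyl for 4-chloropyridin-2-yl cannot be read as a step. The compounds shown leave open what potency, if any, each of them has in this assay.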